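Chain extension in a chloromethyl ketone series on NALM-6 cells

This account rests on a few compounds, and the source may have more. Where it says the series, first, only, none or still open, it means among the compounds named here.

Measured compounds:
compound 1, `CCCCCCSC[C@H](NC(C)=O)C(=O)CCl`, 3300 nM
compound 2, `CCCCCCCSC[C@H](NC(C)=O)C(=O)CCl`, 4800 nM

The account concerns two chloromethyl ketones that share an acetamide and a thioether-bearing side chain and differ only in the alkyl chain on sulfur. In a functional assay on NALM-6 cells (Homo sapiens) (on this read-out higher numbers stand for weaker inhibition and lower numbers for stronger inhibition), compound 1 gives 3300 nM, and compound 2 gives 4800 nM. Going by the values given here, the one step between them, a 1.5-fold higher number from compound 1 to compound 2 (0.16 log units; within the scatter), is the only comparison available, and it does not rise above the scatter. On the numbers shown, compound 2 has the highest value, with compound 1 lying close to it.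

Compound 3, `CCCCCCCCSC[C@H](NC(C)=O)C(=O)CCl`, is not yet measured. It differs from compound 2 by methyl in place of hydrogen on a saturated chain carbon, seven bonds along the chain from a sulfur. The step from compound 1 to compound 2 is the same kind of change made one carbon earlier, and it gave essentially no movement. Among the compounds with values here, no other measured step speaks to this change. The expectation for compound 3 in this assay is therefore a step of about a 1.1-fold higher number from compound 2 to compound 3 (0.06 log units; within the scatter), that is, no change beyond the scatter. Compound 3 is estimated at 5500 nM, with a range from 2500 nM to 12000 nM.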

Compound 3, half-maximal inhibitory concentration: 5600 nM
Beside the measured number, compound 3's estimate is 1.0-fold (0.01 log units) below it; the range from low to high includes it.
By their numbers in this assay, from the lowest: compounds 1, 2 and 3 (each within the scatter of the next).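

In this assay, a second methyl in place of hydrogen, now seven bonds along the chain from a sulfur, gives a 1.2-fold higher number from compound 2 to compound 3 (0.07 log units; within the scatter), so a further step of this kind also stays within the scatter. Read as a single larger change, the two chain extensions taken together give a 1.7-fold higher number from compound 1 to compound 3 (0.23 log units; within the scatter), and even this step stays within the scatter. Going by these compounds alone, the earlier pair offered only one small step, whereas these three compounds show that neither the single-carbon steps nor the two-carbon step separates them on this read-out. Nothing available bears on why the chain makes so little difference here.

What the compounds shown leave open is whether a longer chain, a much shorter one such as methyl on sulfur, or an amine or a carboxylic acid at the far end of the chain would produce a step beyond the scatter. They also leave open whether the chloromethyl ketone and the acetamide matter to the read-out, since both stay the same throughout.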